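Swapping Chloro for Amino on the Fused Ring

The source may report more compounds than this note shows. Statements on the series, on what has been measured and on what is new or still open speak of the compounds shown alone.

Within the data shown here, compound 2 `Nc1nn(C(=O)Nc2ccc(Cc3ccccc3)cc2)c2ccc(Cl)cc12` is the only compound here with a number in a functional assay on HOP-62 cells (Homo sapiens) for antiproliferative activity, read by sulforhodamine B assay, with a stated time of 48 h; a lower number here means that less compound is tolerated, a higher number that more compound is tolerated: it gives 59700 nM. Compound 1 `Nc1nn(C(=O)Nc2ccc(Cc3ccccc3)cc2)c2ccccc12` differs from compound 2 only by a hydrogen where compound 2 carries chloro. In this assay compound 1 reaches just the limit of > 100000 nM. Among the measured compounds shown here, that single comparison, an at least 1.6-fold lower number from compound 1 to compound 2 (0.22 log units; that floor lies within the scatter), is all the measured steps offer, and because its floor sits at the limit of > 100000 nM in this assay, at which 1 of the 2 values shown sits, it says little more than that chloro is tolerated at least as well as hydrogen.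

Compound 3 `Nc1ccc2c(c1)c(N)nn2C(=O)Nc1ccc(Cc2ccccc2)cc1` carries amino in place of chloro on an aromatic carbon, the new group sitting meta to a fused ring and para to a fused ring. For the measured compounds named here, no measured step involves amino at this position, so the chloro-to-hydrogen comparison is the nearest guide, and it moved the number only within the scatter. Compound 3 is therefore expected to show a step of a 1.3-fold higher number from compound 2 to compound 3 (0.13 log units; within the scatter), staying within the scatter. The estimated value for compound 3 in this assay is 80000 nM, with a range from 30000 nM to 300000 nM.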

Compound 3, concentration lethal to 50% of the cells: 65300 nM
Compound 3: the middle estimate sits 1.2-fold (0.09 log units) above what was measured, within the range that was stated.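

In this assay, chloro and amino at this position cannot be told apart, even though amino brings a hydrogen-bond donor and acceptor that chloro lacks: the exchange gives a 1.1-fold higher number from compound 2 to compound 3 (0.04 log units; within the scatter). Measured against hydrogen, amino shows an at least 1.5-fold lower number from compound 1 to compound 3 (0.18 log units; that floor lies within the scatter). That step gives only a floor and not a true size, because compound 1 carries a limit rather than a number: the limit of > 100000 nM in this assay, at which 1 of the 3 values shown sits.

Going by these compounds, how far hydrogen really lies from chloro and amino stays open, since the steps from compound 1 give floors alone. Also open, on these data alone, is whether a methoxy group, a carboxylic acid or a longer chain on this aromatic carbon would move the number beyond the scatter, or would leave it where chloro and amino sit.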